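A Single Methyl Across Two Related Cores

The source may hold more compounds than are shown below. What is called first, only, known or untested is meant among the compounds shown, and "the series" means these compounds.

Compound 1 `CN1CCN(CC#CCn2ccnc2)C1=O` and compound 2 `Cc1cncn1CC#CCN1CCN(C)C1=O` differ in one place: methyl in place of hydrogen on an aromatic carbon. In a functional assay on the whole organism for antagonist activity, with Mus musculus as the target (a higher number here means that more compound is needed for the effect, a lower number that less compound is needed), compound 1 reaches only a limit, > 100 mg/kg. Compound 2 gives 14 mg/kg in this assay, so the change brought an at least 7.1-fold lower number from compound 1 to compound 2 (0.85 log units; beyond the scatter). Compound 3 `Cn1ccn(CC#CCn2ccnc2)c1=O` has a core whose difference from the core of compound 1 is not broken down here. In this assay compound 3 also reaches only a limit, > 100 mg/kg. Compound 4 `Cc1cncn1CC#CCn1ccn(C)c1=O` carries the same kind of change relative to compound 3: methyl in place of hydrogen on an aromatic carbon. Since two of the three values sit at the limit of > 100 mg/kg in this assay, at which 2 of the 3 values shown sit, the start of this step is itself unknown. Compound 4 is expected to give 30 mg/kg in this assay, within 8 mg/kg to 150 mg/kg. This estimate means a step of an at least 3.3-fold lower number from compound 3 to compound 4 (0.52 log units; beyond the scatter), placed beside the earlier step because the same change gave an at least 7.1-fold lower number from compound 1 to compound 2 (0.85 log units; beyond the scatter).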

Compound 4, dose for half-maximal effect: 8 mg/kg
Beside the measured number, compound 4's estimate is 3.8-fold (0.57 log units) above it, and the stated range covers the measured number.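

In this assay, methyl in place of hydrogen on an aromatic carbon again goes with a lower number, an at least 12-fold lower number from compound 3 to compound 4 (1.09 log units; beyond the scatter). On these two pairs, the direction of the change therefore carries over from the core of compound 1 to the core of compound 3, with both steps beyond the scatter. It does not show that the size of the step carries over, because each step starts from a limit: the same change on two cores in this assay, an at least 7.1-fold lower number (0.85 log units; beyond the scatter) from compound 1 to compound 2 and an at least 12-fold lower number (1.09 log units; beyond the scatter) from compound 3 to compound 4; the limit leaves it open whether they differ

The compounds shown leave open how an ethyl group or a chlorine atom on that aromatic carbon would read in this assay. They also leave open whether the methyl step would hold on a third core.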